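The source may hold more compounds than are shown below. What is called first, only, known or untested is meant among the compounds shown, and "the series" means these compounds.

Compound 1 `O=C(c1ccncc1)N1N=C(c2cc3ccccc3o2)CC1c1cccc([N+](=O)[O-])c1` and compound 3 `CCn1cc(C(=O)N2N=C(c3cc4ccccc4o3)CC2c2cccc([N+](=O)[O-])c2)c(=O)c2ccc(C)nc21` share the benzofuran-bearing five-membered ring; the difference between their two cores is not broken down here. In an ADME assay on Vero cells (Chlorocebus sabaeus) for cytotoxicity, read by MTT assay, with a stated time of 72 h (a higher number here means a weaker inhibitor, a lower number a stronger inhibitor), compound 1 gives only a limit, > 240000 nM. Compound 3 likewise gives only a limit in this assay, > 164000 nM. Compound 2 `COc1ccc(C2CC(c3cc4ccccc4o3)=NN2C(=O)c2ccncc2)c(O)c1` carries 2-hydroxy-4-methoxyphenyl in place of 3-nitrophenyl on a saturated ring carbon. In this assay compound 2 also gives only a limit, > 190000 nM. The step that the two limits leave unreadable from compound 1 to compound 2 cannot be sized because the limit of > 240000 nM in this assay, at which 1 of the 3 values shown sits, and the limit of > 190000 nM in this assay, at which 1 of the 3 values shown sits, are both limits. Compound 4 `CCn1cc(C(=O)N2N=C(c3cc4ccccc4o3)CC2c2ccc(OC)cc2O)c(=O)c2ccc(C)nc21` carries the same kind of change, (2-hydroxy-4-methoxyphenyl in place of 3-nitrophenyl on a saturated ring carbon); around the place the changed carbon is next to the ring atom that bears a large group, where in compound 1 that atom bears a (pyridin-4-yl)carbonyl group. Given that compound 3 sits at the limit of > 164000 nM in this assay, at which 1 of the 3 values shown sits, and compound 2 at the limit of > 190000 nM in this assay, at which 1 of the 3 values shown sits, a flat step that the limit leaves unreadable from compound 3 to compound 4 is expected. Compound 4 is estimated at 200000 nM, between 80000 nM and 400000 nM.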

Compound 4, half-maximal inhibitory concentration: > 154000 nM
Compound 4 gave a limit, no number (the forecaster's own chance of this, stated with the estimate: 80%); the middle value lies beyond the limit too.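

In this assay compound 4 gives only a limit, > 154000 nM. Among these compounds, compound 3 also gives only a limit, > 164000 nM, so no step from compound 3 to compound 4 can be read. The compounds shown leave open where any of them reaches half-maximal inhibition in this assay.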